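A few compounds are considered here, and "the series" means these few. Any claim that something is new, unique, unknown or untested is made for them only; others in the source may bear on it.

Compound 1 `CCc1ccc(Nc2cc(NC(=O)Nc3cc(OC)cc(OC)c3)ncn2)cc1`: 50.1%
Compound 2 `COc1cc(NC(=O)Nc2cc(Nc3cc(C(F)(F)F)ccc3OC)ncn2)cc(OC)c1`: 60%
Compound 3 `COc1ccc(Nc2cc(NC(=O)Nc3c(Cl)cccc3Cl)ncn2)cc1C`: 50%

Of the compounds shown here, three built on a shared core have been tested in a functional assay on NCI-H226 cells (Homo sapiens) for inhibition, read by MTT assay, with a stated time of 48 h, tested at 10 uM; on this read-out lower numbers stand for less inhibition and higher numbers for more inhibition at the one concentration tested (going by the name of the read-out). Compound 1 gives 50.1%, compound 3 gives 50% and compound 2 gives 60%. Compound 1 differs from compound 3 by a hair and from compound 2 by a larger but still modest margin, and both gaps fall inside the usual scatter of this assay, so the three numbers cannot be told apart with confidence.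

Compound 4 `CCc1cccc(Nc2cc(NC(=O)Nc3cc(OC)cc(OC)c3)ncn2)c1` has not yet been measured. It differs from compound 1 in one place: 3-ethylphenyl in place of 4-ethylphenyl on a nitrogen on an aromatic ring. No measured pair shows what such a change does on this core, so there is no direct guide, and the three numbers in hand give little reason to expect a shift beyond the scatter in either direction. The step from compound 1 to compound 4 is therefore expected to be small, a number 0.1 percentage points lower from compound 1 to compound 4 (within the scatter). For compound 4 in this assay the estimate is 50%, with a plausible range from 35% to 65%.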

Compound 4, a percentage reported as inhibition, at one concentration (the size of the read-out at that concentration, not a potency): 36.7%
Compound 4: middle estimate off by 13.3 percentage points, on the high side; the measured number falls inside the stated range.
By their numbers in this assay, from the lowest: compound 4; then compounds 3, 1 and 2 (each within the scatter of the next).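

On the shared core, the place of the ethyl group on this ring matters: in this assay, 3-ethylphenyl in place of 4-ethylphenyl on a nitrogen on an aromatic ring gives a number 13.4 percentage points lower from compound 1 to compound 4 (beyond the scatter). Among the compounds shown here, this is the first pair measured that differs in one place, and its two compounds hold the same atoms, joined differently, so the step comes from a change in arrangement and not in composition. Nothing in the data explains how that rearrangement lowers the inhibition.

This single pair cannot show whether the same shift of a group would lower the number with the other substituents on the core. Also open, on these data alone, is how a longer chain such as propyl, an amine or a carboxylic acid would read at either of these two ring places.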